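Sulfonyl substituent changes on the shared core

The source may report more compounds than this note shows. Statements on the series, on what has been measured and on what is new or still open speak of the compounds shown alone.

Measured compounds:
compound 1 `CC1(C)C=C(n2ccccc2=O)c2cc(S(=O)(=O)N=[N+]=[N-])ccc2O1`: 16.2 nM
compound 2 `COc1ccc(NS(=O)(=O)c2ccc3c(c2)C(n2ccccc2=O)=CC(C)(C)O3)cc1`: 117 nM
compound 3 `CN(C)S(=O)(=O)c1ccc2c(c1)C(n1ccccc1=O)=CC(C)(C)O2`: 16.2 nM

All three were run in a functional assay with Rattus norvegicus as the target; a lower number here means that less compound is needed, a higher number that more compound is needed for the effect. Compound 3 stands level with compound 1 (no change at the digits printed from compound 1 to compound 3 (within the scatter)), and these two together give the lowest numbers of the three; compound 2 sits furthest from compound 3 (a 7.2-fold lower number from compound 2 to compound 3 (0.86 log units; beyond the scatter)).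

Compound 4 `CC1(C)C=C(n2ccccc2=O)c2cc(S(=O)(=O)NC(=O)Nc3ccccc3)ccc2O1` is unmeasured; relative to compound 3 the change is (phenylcarbamoyl)amino in place of dimethylamino on a sulfonyl sulfur. Within the data shown here, the steps that bear on it are the exchanges of a small sulfonyl substituent for an arylamino one: a 7.2-fold higher number from compound 1 to compound 2 (0.86 log units; beyond the scatter) and a 7.2-fold lower number from compound 2 to compound 3 (0.86 log units; beyond the scatter). The entering group again carries a six-membered aromatic ring of carbon only and hydrogen-bond donors. For compound 4 a rise of comparable size is therefore expected in this assay, a 6.2-fold higher number from compound 3 to compound 4 (0.79 log units; beyond the scatter). Compound 4 is estimated at 100 nM, with a range of 30 nM to 400 nM.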

Compound 4, half-maximal effective concentration: 1410 nM
The estimate for compound 4 lay 14-fold (1.15 log units) below the measured number, and the stated range ends below it.
By their numbers in this assay, from the lowest: compounds 1 and 3 (each within the scatter of the next); then compound 2; then compound 4.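

In this assay the position on the sulfonyl sulfur turns out far less forgiving of (phenylcarbamoyl)amino than compound 2 suggested for an arylamino group, with an 87-fold higher number from compound 3 to compound 4 (1.94 log units; beyond the scatter) and an 87-fold higher number from compound 1 to compound 4 (1.94 log units; beyond the scatter) in the same series. A six-membered aromatic ring on the substituent does not by itself fix the level, since a 12-fold higher number from compound 2 to compound 4 (1.08 log units; beyond the scatter) separates two compounds that both carry one. No measurement at hand accounts for this rise.

From the compounds shown here alone, whether the rise follows the carbonyl, the added nitrogen or the phenyl ring stays open. An acetyl group on the sulfonamide nitrogen, or a morpholine on the sulfonyl sulfur, would help to separate these.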